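Extending the chain on compound 3 with a hydroxymethyl group

A few compounds are considered here, and "the series" means these few. Any claim that something is new, unique, unknown or untested is made for them only; others in the source may bear on it.

Measured compounds:
- compound 1, `COC(=O)CCCc1onc(NS(=O)(=O)c2ccc(C(C)(C)C)cc2)c1Sc1cccc(OC)c1`, 310 nM
- compound 2, `CCc1onc(NS(=O)(=O)c2ccc(C(C)(C)C)cc2)c1Sc1cccc(OC)c1`, 2800 nM
- compound 3, `COc1cccc(Sc2c(NS(=O)(=O)c3ccc(C(C)(C)C)cc3)noc2C)c1`, 300 nM

Of the compounds shown here, three share one core and have been tested in an assay on COS-7 cells for displacement of a labelled ligand from Endothelin receptor type B (Sus scrofa); a higher number here means a weaker inhibitor, a lower number a stronger inhibitor. Compound 3 `COc1cccc(Sc2c(NS(=O)(=O)c3ccc(C(C)(C)C)cc3)noc2C)c1` gives the lowest number of the three, though compound 1 lies within the scatter of it, so the two cannot be ordered; only compound 2 is clearly apart, the step being a 9.3-fold lower number from compound 2 to compound 3 (0.97 log units; beyond the scatter).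

Compound 4 `COc1cccc(Sc2c(NS(=O)(=O)c3ccc(C(C)(C)C)cc3)noc2CCO)c1` is the compound not yet measured. It differs from compound 3 by hydroxymethyl in place of hydrogen on a saturated chain carbon bound to an aromatic carbon.

Among the measured compounds shown here, two measured steps bear on this change. The step of a 9.3-fold lower number from compound 2 to compound 3 (0.97 log units; beyond the scatter) shows that a methyl on that chain carbon costs potency when set against hydrogen. The step of a 1.0-fold lower number from compound 1 to compound 3 (0.01 log units; within the scatter), on the other hand, shows that a longer chain bearing an ester on the same carbon is tolerated without any shift beyond the scatter. A two-carbon chain ending in a hydroxyl sits between these two cases. Compound 4 is therefore expected to give a somewhat higher number than compound 3, a step of a 2.3-fold higher number from compound 3 to compound 4 (0.37 log units; beyond the scatter), less than the step to compound 2. For compound 4 the estimate in this assay is 700 nM, within a range of 250 nM to 2500 nM.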

Compound 4, half-maximal inhibitory concentration: 430 nM
The estimate for compound 4 lay 1.6-fold (0.21 log units) above the measured number; the range from low to high includes it.
By their numbers in this assay, from the lowest: compounds 3, 1 and 4 (each within the scatter of the next); then compound 2.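

In this assay, hydroxymethyl in place of hydrogen on a saturated chain carbon bound to an aromatic carbon is tolerated, with a 1.4-fold higher number from compound 3 to compound 4 (0.16 log units; within the scatter), so this position accepts a 2-hydroxyethyl chain as well as the methyl of compound 3. The ester of compound 1 is not needed to reach this level, as hydroxy in place of (methoxycarbonyl)methyl gives a 1.4-fold higher number from compound 1 to compound 4 (0.14 log units; within the scatter), and the two compounds cannot be ordered. The new result also shows that the poorer number of compound 2 does not extend to every chain of this length: hydroxy in place of hydrogen on the chain carbon two bonds along from the aromatic carbon gives a 6.5-fold lower number from compound 2 to compound 4 (0.81 log units; beyond the scatter), a change beyond the scatter that compound 2 alone could not reveal.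

Going by these compounds, whether an amine or a carboxylic acid in place of that hydroxy, or a longer chain ending in hydroxy, would stay within the scatter of compound 3 remains open. Nothing given here accounts for why the hydroxy separates compound 4 from compound 2.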